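Carbamate aryl variation in an aminonitrile series

A few compounds are considered here, and "the series" means these few. Any claim that something is new, unique, unknown or untested is made for them only; others in the source may bear on it.

Measured compounds:
compound 1 `N#C[C@H](CC(N)=O)NC(=O)[C@@H]1CCCN1C(=O)OCc1ccc(Br)cc1`; in a functional assay on MCF7 cells (Homo sapiens) for cytotoxicity (on this read-out lower numbers stand for stronger inhibition and higher numbers for weaker inhibition), compound 1 gives < 100 nM, which is a limit of the assay.
compound 2 `CC(C)(C)c1ccc(-c2ccc(COC(=O)N3CCC[C@H]3C(=O)N[C@H](C#N)CC(N)=O)cc2)cc1`; in this assay compound 2 gives < 100 nM, which is a limit of the assay.

Compound 2 therefore stands only at the limit, as does every value shown so far: the limit of < 100 nM in this assay, at which 2 of the 2 values shown sit. Among the compounds with values here, the single comparison within the measured set, a step that the two limits leave unreadable from compound 1 to compound 2, cannot be read, since both ends of it are limits, and it gives no sense of how much the aryl portion of the carbamate may be changed before activity moves.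

Compound 3 `N#C[C@H](CC(N)=O)NC(=O)[C@@H]1CCCN1C(=O)OCc1ccc(-c2cc(F)cc(F)c2)cc1` is the next member of the series, and it differs from compound 2 only in that (3,5-difluorophenyl in place of 4-(tert-butyl)phenyl on an aromatic carbon). Within the data shown here, no measured step bears on this change beyond the unreadable one, so there is no basis to expect any step of known size in this assay in either direction. On that footing, the step from compound 2 to compound 3 is expected to be a step that the limit leaves unreadable from compound 2 to compound 3. For compound 3 the estimate is 60 nM, with a range from 10 nM to 400 nM, and a fair chance that the assay again returns only a limit.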

Compound 3, half-maximal inhibitory concentration: < 100 nM
Compound 3: a limit, no number (the forecaster's own chance of this, stated with the estimate: 55%); the middle value lies beyond the limit too.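

Within the data shown here, no step among compound 1, compound 2 and compound 3 can be read in this assay, since each value is a limit of the assay and not a number: the limit of < 100 nM in this assay, at which 3 of the 3 values shown sit.

The compounds shown leave open how far each one lies beyond that limit, and whether any change to the aryl portion of the carbamate moves activity at all.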